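This account rests on a few compounds, and the source may have more. Where it says the series, first, only, none or still open, it means among the compounds named here.

For the measured compounds named here, in a functional assay on MCF7 cells (Homo sapiens) for cytotoxicity, read by MTT assay, with a stated time of 72 h (a lower number here means a stronger inhibitor, a higher number a weaker inhibitor), compound 3 `COC(=O)c1sc2cc(C)ccc2c1Nc1cc(OC)c(OC)c(OC)c1` gives 1.2 nM, the second highest of the three numbers so far. Compound 1 `COC(=O)c1sc2cc(OC)ccc2c1Nc1cc(OC)c(OC)c(OC)c1` gives 0.7 nM, within the scatter of compound 3, while compound 2 `CCOC(=O)c1sc2ccccc2c1Nc1cc(OC)c(OC)c(OC)c1` gives 6390 nM, far beyond it. Compound 4 `COC(=O)c1sc2ccccc2c1Nc1cc(OC)c(OC)c(OC)c1` is reached from compound 3 by hydrogen in place of methyl on an aromatic carbon. Going by the values given here, the only measured single-place step at this carbon, methyl in place of methoxy, gave a 1.7-fold higher number from compound 1 to compound 3 (0.23 log units; within the scatter), within the scatter, and it does not test a bare hydrogen there. The closest evidence is compound 2, which also carries hydrogen on that carbon but has an ethyl ester where compound 4 has a methyl ester, so two places differ from compound 3. With compound 2 at 6390 nM, a large step to a higher number in this assay is expected. The size of that step is less certain. Among the compounds with values here, no measured compound carries hydrogen on that carbon together with a methyl ester. The estimated step is a 420-fold higher number from compound 3 to compound 4 (2.62 log units; beyond the scatter). Compound 4 is expected at 500 nM, with an estimated range of 20 nM to 8000 nM.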

Compound 4, half-maximal inhibitory concentration: 795 nM
Beside the measured number, compound 4's estimate is 1.6-fold (0.20 log units) below it; the measured number falls inside the stated range.
By their numbers in this assay, from the lowest: compounds 1 and 3 (each within the scatter of the next); then compound 4; then compound 2.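

In this assay, a bare hydrogen on this aromatic carbon is now tested with the methyl ester held constant: the change gives a 660-fold higher number from compound 3 to compound 4 (2.82 log units; beyond the scatter), and replacing methoxy gives a 1100-fold higher number from compound 1 to compound 4 (3.06 log units; beyond the scatter). Methyl and methoxy at this carbon stand apart from hydrogen by far more than they differ from each other, a step of a 1.7-fold higher number from compound 1 to compound 3 (0.23 log units; within the scatter). The ester also matters with hydrogen on this carbon, though by less: shortening ethyl ester to methyl ester gives an 8.0-fold lower number from compound 2 to compound 4 (0.91 log units; beyond the scatter).

From the compounds shown here alone, whether other groups on this carbon, such as an amine, chlorine or a longer chain, keep the low numbers remains open, as does the effect of a carboxylic acid in place of the ester. No measurement at hand accounts for the size of these steps.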